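The source may hold more compounds than are shown below. What is called first, only, known or untested is meant among the compounds shown, and "the series" means these compounds.

Measured compounds:
- compound 1, `COc1cc(-c2cc(/C=C/C(=O)c3ccc(N)cc3)[nH]n2)cc(OC)c1OC`, -73%
- compound 2, `COc1ccc(-c2cc(/C=C/C(=O)c3ccc(OC)c(OC)c3)[nH]n2)cc1`, -64%

Both were tested in a functional assay on NCI-H226 cells (Homo sapiens) for cytotoxicity, read by sulforhodamine B assay, with a stated time of 48 h, tested at 10 uM; a lower number here means a stronger effect, a higher number a weaker effect of the compound at the concentration tested. Compound 1 gives the lower of the two numbers, -73%, but compound 2 with -64% sits within the scatter of it, so the two show much the same effect.

Compound 3, `COc1cc(-c2cc(/C=C/C(=O)c3ccc(Cl)c(Cl)c3)[nH]n2)cc(OC)c1OC`, has not been measured. It differs from compound 1 in one place: 3,4-dichlorophenyl in place of 4-aminophenyl on a carbonyl carbon. For the measured compounds named here, nothing among the measured pairs records what this particular change does, since no two measured compounds differ only there.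

For compound 3 the expectation is a weak shift toward a higher number, around a number 15 percentage points higher from compound 1 to compound 3 (beyond the scatter), but a change no larger than the scatter would not surprise. The estimate for compound 3 in this assay is -58%, expected to lie between -88% and -25%.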

Compound 3, a percentage reported as activity, at one concentration (the size of the read-out at that concentration, not a potency): 67%
Compound 3: the middle estimate sits 125 percentage points below what was measured, and the stated range ends below it.
By their numbers in this assay, from the lowest: compounds 1 and 2 (each within the scatter of the next); then compound 3.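

The group on the carbonyl carbon matters a great deal in this assay: 3,4-dichlorophenyl in place of 4-aminophenyl gives a number 140 percentage points higher from compound 1 to compound 3 (beyond the scatter) and reverses the sign of the read-out, with compound 1 at -73% and compound 3 at 67% in the same test. On the core of compound 1, then, this place does not accept just any aromatic group, and the outcome at the tested concentration depends strongly on which one sits there. No measurement at hand explains why this swap has so large an effect.

The swap removes the amino group and brings in two chlorines at once, so the compounds shown cannot tell which of these accounts for the step. A plain phenyl or a hydroxyphenyl on the same carbonyl carbon would help to separate the two.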